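Chloro in Place of Trifluoromethyl: Expected Tissue Distribution

The source may report more compounds than this note shows. Statements on the series, on what has been measured and on what is new or still open speak of the compounds shown alone.

Compound 1 `N#Cc1ncc(N2C(=O)C3(CCC3)N(c3ccc(OC4CCNCC4)nc3)C2=S)cc1C(F)(F)F` gives 6.11 L/kg in an ADME assay on the whole organism (Mus musculus, strain CD1) for pharmacokinetics, at a dose of 2 mg/kg by the intravenous route; on this read-out higher numbers stand for wider distribution into tissues and lower numbers for narrower distribution. This puts compound 1 second highest of three numbers, though its gap to either neighbour is within the scatter: compound 3 `CN1CCC(Oc2ccc(N3C(=S)N(c4cnc(C#N)c(C(F)(F)F)c4)C(=O)C34CCC4)cn2)CC1` gives 7.69 L/kg and compound 2 `COc1cc(N2C(=O)C3(CCC3)N(c3ccc(OC4CCN(C)CC4)cc3)C2=S)cnc1C#N` gives 3.7 L/kg. Among the compounds with values here, the only measured step in this set, a 1.3-fold higher number from compound 1 to compound 3 (0.10 log units; within the scatter), concerns a different kind of change and so says nothing about the change made here. Compound 4 `N#Cc1ncc(N2C(=O)C3(CCC3)N(c3ccc(OC4CCNCC4)nc3)C2=S)cc1Cl` differs from compound 1 by chloro in place of trifluoromethyl on an aromatic carbon. Within the data shown here, no measured step bears on this change, so the expectation rests on compound 1 alone, and the step of a 1.1-fold lower number from compound 1 to compound 4 (0.05 log units; within the scatter) is expected to lie within the scatter. Compound 4 is therefore estimated at 5.5 L/kg, with a range from 3 L/kg to 10 L/kg.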

Compound 4, volume of distribution at steady state: 6.92 L/kg
The estimate for compound 4 lay 1.3-fold (0.10 log units) below the measured number; the measured number falls inside the stated range.
By their numbers in this assay, from the lowest: compounds 2, 1, 4 and 3 (each within the scatter of the next, the first and the last beyond it).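

At the aromatic carbon ortho to a cyano group, the step of a 1.1-fold higher number from compound 1 to compound 4 (0.05 log units; within the scatter) shows that chloro in place of trifluoromethyl leaves this assay within the scatter. In this one pair, a single chlorine atom and the four heavy atoms of trifluoromethyl give numbers that cannot be told apart. Nothing measured here offers an explanation for this result. On these data alone, whether a bromo or a methyl group on this same carbon would also stay within the scatter remains open. So does whether chloro behaves alike with a methyl on the ring amine nitrogen, as in compound 3.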